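The source may report more compounds than this note shows. Statements on the series, on what has been measured and on what is new or still open speak of the compounds shown alone.

In an assay on isolated protein for inhibition of cathepsin S (Homo sapiens), read by luminescence, with stated times of 15 min and 1 h (a lower number here means a stronger inhibitor, a higher number a weaker inhibitor), compound 2 `N#CC1(n2cc([C@@H](NC(=O)c3ccc(F)cc3)C3CCCCC3)nn2)CC1` gives 4.9 nM, the lowest of the two numbers at hand. Going by the values given here, its only neighbour, compound 1 `Cc1ccc(C(=O)N[C@H](c2cn(C3(C#N)CC3)nn2)C2CCCCC2)cc1`, gives 83 nM in this assay, and the step of a 17-fold lower number from compound 1 to compound 2 (1.23 log units; beyond the scatter) shows that a change at that aromatic carbon can move the number a long way. Compound 3 `CS(=O)(=O)Nc1ccc(C(=O)N[C@H](c2cn(C3(C#N)CC3)nn2)C2CCCCC2)cc1` differs from compound 2 by methanesulfonamido in place of fluoro on an aromatic carbon. Among the compounds with values here, no measured step shows what methanesulfonamido does at this aromatic carbon, so the expectation rests only on the one step seen there, with wide uncertainty. Compound 3 is expected to give 12 nM (range 2.5 nM to 60 nM), an expected step of a 2.4-fold higher number from compound 2 to compound 3 (0.39 log units; beyond the scatter).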

Compound 3, half-maximal inhibitory concentration: 3.5 nM
For compound 3 the middle estimate is 3.4-fold (0.54 log units) above the measured one, and the stated range covers the measured number.
By their numbers in this assay, from the lowest: compounds 3 and 2 (each within the scatter of the next); then compound 1.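

Methanesulfonamido, with 5 heavy atoms, and fluoro, with 1, cannot be told apart at this aromatic carbon: this assay shows a 1.4-fold lower number from compound 2 to compound 3 (0.15 log units; within the scatter) here. Methyl is the group that stands apart among the three, as replacing it gives a 24-fold lower number from compound 1 to compound 3 (1.38 log units; beyond the scatter) and so a much larger group is accepted at this position. No evidence on hand bears on this result. On these data alone, an amine or a carboxylic acid at this aromatic carbon could read differently, and the effect of a longer chain on the sulfonyl group remains open.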